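This account rests on a few compounds, and the source may have more. Where it says the series, first, only, none or still open, it means among the compounds named here.

Of the compounds shown here, three have been measured in a functional assay on HepG2 cells (Homo sapiens) for cytotoxicity, read by MTT assay, with a stated time of 48 h; a higher number here means a weaker inhibitor, a lower number a stronger inhibitor. Compound 1 `CCC(=O)N1N=C(C)CC1c1cc(Br)cc(Br)c1O` gives 41400 nM. Compound 2 `CC1=NN(C(=O)CN2CCN(C(=O)OC(C)(C)C)CC2)C(c2ccccc2O)C1` gives 5000 nM. Compound 3 `CCCNCC(=O)N1N=C(c2cc3ccccc3oc2=O)CC1c1ccccc1` gives 10800 nM. Among these three numbers, compound 3 stands second highest: compound 2 shows a lower number, and compound 1 a higher one, and both of those gaps lie beyond the usual scatter of repeated measurements.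

Compound 4 `CN1CCN(CC(=O)N2N=C(c3cc4ccccc4oc3=O)CC2c2ccccc2)CC1` has not yet been measured. It differs from compound 3 in one place: 4-methylpiperazin-1-yl in place of propylamino on a saturated chain carbon bound to a carbonyl carbon. Within the data shown here, no pair of measured compounds differs in exactly this way, so there is no measured step to lean on.

Given that the rest of the structure is unchanged, the expected step in this assay from compound 3 to compound 4 is small, with a slight lean toward a lower number, and it may well fall within the scatter, at about a 1.4-fold lower number from compound 3 to compound 4 (0.13 log units; within the scatter). On that basis, compound 4 is estimated to give 8000 nM, with a plausible range from 3000 nM to 25000 nM.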

Compound 4, half-maximal inhibitory concentration: 33100 nM
For compound 4 the middle estimate is 4.1-fold (0.62 log units) below the measured one; measured number outside the range, above it.
By their numbers in this assay, from the lowest: compound 2; then compound 3; then compounds 4 and 1 (each within the scatter of the next).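

In this assay, the group on this saturated chain carbon bound to a carbonyl carbon does matter: replacing propylamino with 4-methylpiperazin-1-yl gives a 3.1-fold higher number from compound 3 to compound 4 (0.49 log units; beyond the scatter) and so points toward weaker inhibition. Among these compounds, the step is modest, but it is the first measured sign that this position responds to a change of group. Because it rests on a single pair, it sets no trend, and the swap changes the heavy-atom count, the ring and the hydrogen-bond donors all at once, with no measurement available to explain the shift.

On these data alone, it remains open which of those differences goes with the higher number. A piperidin-1-yl ring, a morpholin-4-yl ring or a small open-chain amine such as dimethylamino at this position could help separate them.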